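A few compounds are considered here, and "the series" means these few. Any claim that something is new, unique, unknown or untested is made for them only; others in the source may bear on it.

Compound 1 `COc1ccccc1Cn1ccc2nc(-c3ccccc3)nc-2c1` gives in an ADME assay on MDBK cells (Bos taurus) for cytotoxicity (on this read-out lower numbers stand for higher toxicity in this test and higher numbers for lower toxicity in this test), only a limit, > 100000 nM.
Compound 2 `Fc1ccccc1Cn1ccc2nc(-c3ccccc3)nc-2c1` gives in this assay only a limit, > 100000 nM.
Compound 3 `N#Cc1ccccc1Cn1ccc2nc(-c3ccccc3)nc-2c1` gives in this assay only a limit, > 100000 nM.

Going by the values given here, compound 3 thus stands at a limit, and the two other values shown sit at the same limit, so no compound among the three is placed on a number (the limit of > 100000 nM in this assay, at which 3 of the 3 values shown sit). The move to compound 4 `CC(C)N(CCn1ccc2nc(-c3ccccc3)nc-2c1)C(C)C` is (diisopropylamino)methyl in place of 2-cyanophenyl on a saturated chain carbon bound to an aromatic nitrogen. The measured steps touch the same saturated chain carbon, but none has a readable size: a step that the two limits leave unreadable from compound 1 to compound 2, a step that the two limits leave unreadable from compound 1 to compound 3, a step that the two limits leave unreadable from compound 2 to compound 3. They give no direction, so no step beyond the scatter can be expected in this assay. Compound 4 is expected to give about 100000 nM, within 30000 nM to 300000 nM. The expected step is therefore a number no higher from compound 3 to compound 4 (the limit leaves the size open).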

Compound 4, half-maximal cytotoxic concentration: > 100000 nM
Compound 4: no number, only a limit; the forecaster's own chance of this, stated with the estimate: 60%; the middle value lies on the limit itself.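

No step can be read from compound 4 to compound 1, compound 2 or compound 3, because all four stand at one limit and not on a number: the limit of > 100000 nM in this assay, at which 4 of the 4 values shown sit.

The compounds shown leave open whether any of these groups changes the read-out in this assay at all.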